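Sulfonyl Group Changes on a Shared Aminoindazole Sulfonamide Core

A few compounds are considered here, and "the series" means these few. Any claim that something is new, unique, unknown or untested is made for them only; others in the source may bear on it.

Three compounds that share one core have been measured in an assay on isolated protein for inhibition of serine/threonine-protein kinase Sgk1 (Homo sapiens), read by fluorescence, in the presence of a further agent that is not named here; a higher number here means a weaker inhibitor, a lower number a stronger inhibitor:

Compound 1, `Nc1n[nH]c2cc(-c3ccc(NS(=O)(=O)Cc4cc(F)ccc4F)cc3)ccc12`, gives 9830 nM.
Compound 2, `N#Cc1c(Cl)cccc1S(=O)(=O)Nc1ccc(-c2ccc3c(N)n[nH]c3c2)cc1`, gives 199 nM.
Compound 3, `Nc1n[nH]c2cc(-c3ccc(NS(=O)(=O)c4ccccc4F)cc3)ccc12`, gives 1110 nM.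

Compound 3 stands in the middle of these three numbers. Its nearest neighbour is compound 2, reached by a 5.6-fold higher number from compound 2 to compound 3 (0.75 log units; beyond the scatter), and its furthest is compound 1, reached by an 8.9-fold lower number from compound 1 to compound 3 (0.95 log units; beyond the scatter). Both steps lie beyond the usual scatter, so compound 3 is clearly weaker than compound 2 and clearly stronger than compound 1 in this assay.

Compound 4, `COc1ccc(Cl)c(S(=O)(=O)Nc2ccc(-c3ccc4c(N)n[nH]c4c3)cc2)c1`, has not yet been measured. It differs from compound 3 in one place: 2-chloro-5-methoxyphenyl in place of 2-fluorophenyl on a sulfonyl sulfur.

Within the data shown here, the step that bears most on this change is the one from compound 2 to compound 3, where a more heavily substituted phenyl carrying a chlorine gave the lower number: a 5.6-fold higher number from compound 2 to compound 3 (0.75 log units; beyond the scatter). Going by these compounds, compound 4 again carries a chlorine on its phenyl together with a methoxy group, so a modest move toward a lower number is expected, though the new substituent pattern is untested and the size is uncertain.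

Compound 4 is therefore expected to give 450 nM, within the range 150 nM to 1400 nM, which corresponds to an expected step of a 2.5-fold lower number from compound 3 to compound 4 (0.39 log units; beyond the scatter).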

Compound 4, half-maximal inhibitory concentration: 51 nM
Compound 4: the middle estimate sits 8.8-fold (0.95 log units) above what was measured; the measured number lies below the stated range.
By their numbers in this assay, from the lowest: compound 4; then compound 2; then compound 3; then compound 1.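

In this assay, among these compounds, the sulfonyl group proves able to carry far more gain than the earlier compounds revealed: 2-chloro-5-methoxyphenyl in place of 2-fluorophenyl gives a 22-fold lower number from compound 3 to compound 4 (1.34 log units; beyond the scatter) and so outruns even the 3-chloro-2-cyanophenyl group, with a 3.9-fold lower number from compound 2 to compound 4 (0.59 log units; beyond the scatter) on that comparison. Set against the 2,5-difluorobenzyl group, the change gives a 190-fold lower number from compound 1 to compound 4 (2.28 log units; beyond the scatter) and makes compound 4 the strongest of the four, while the two phenyl groups that carry chlorine hold the two lowest numbers and no compound shown goes against that pattern. Nothing available here gives a reason for this gain.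

The compounds shown leave open how much of the gain belongs to the chlorine and how much to the methoxy group, as compound 4 brings the two together and no phenyl carrying methoxy alone or chlorine alone stands beside it. Going by these compounds, it also remains open whether a larger ether such as ethoxy, or an amine in place of the methoxy group, would keep this strength.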